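From Ester to Free Acid: Expecting the Next Cytotoxicity Number

The source may report more compounds than this note shows. Statements on the series, on what has been measured and on what is new or still open speak of the compounds shown alone.

Of the compounds shown here, three have been tested in an ADME assay on Vero cells (Chlorocebus sabaeus) for cytotoxicity, read by MTT assay; on this read-out higher numbers stand for weaker inhibition and lower numbers for stronger inhibition. Compound 1 `COc1ccc(-c2oc3c(CC=C(C)C)c(OCCCOC(=O)CCCC(=O)O)cc(O)c3c(=O)c2OCCCOC(=O)CCCC(=O)O)cc1` gives 6300 nM in this assay, and compound 2 `CCOC(=O)C(C)Oc1c(-c2ccc(OC)cc2)oc2c(CC=C(C)C)c(O)cc(O)c2c1=O` gives 6500 nM. Compound 3 `CCOC(=O)C(C)Oc1cc(O)c2c(=O)c(O)c(-c3ccc(OC)cc3)oc2c1CC=C(C)C` gives 1400 nM, the lowest of the three numbers; its gaps to compound 1 and to compound 2 both lie beyond the usual scatter, so compound 3 is the strongest inhibitor of the set. Compound 4 `COc1ccc(-c2oc3c(CC=C(C)C)c(OC(C)C(=O)O)cc(O)c3c(=O)c2O)cc1` is not yet measured and differs from compound 3 in one place: hydrogen in place of ethyl on an oxygen next to a carbonyl group. Within the data shown here, no pair of measured compounds isolates such a change, so the guide is thin. A modest step toward weaker inhibition is expected, a 2.5-fold higher number from compound 3 to compound 4 (0.40 log units; beyond the scatter). Compound 4 is therefore estimated at 3500 nM, within a range from 1400 nM to 10000 nM.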

Compound 4, half-maximal inhibitory concentration: 19300 nM
The estimate for compound 4 lay 5.5-fold (0.74 log units) below the measured number; measured number above the stated range.
By their numbers in this assay, from the lowest: compound 3; then compounds 1 and 2 (each within the scatter of the next); then compound 4.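

Replacing ethyl with hydrogen on the oxygen next to the carbonyl group, which turns 1-(ethoxycarbonyl)ethyl into 1-carboxyethyl, gives in this assay a 14-fold higher number from compound 3 to compound 4 (1.14 log units; beyond the scatter) and so a clear shift toward weaker inhibition. Among these compounds, this single pair shows that the end of this side chain strongly affects the read-out, which no earlier pair could isolate. No measurement at hand accounts for the size of this step. Still open, as far as these compounds go, is whether a methyl ester or an amide at this place would behave more like compound 3 or compound 4.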